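From 3,4-dichlorophenyl to 4-bromophenyl on the styryl chain

The source may report more compounds than this note shows. Statements on the series, on what has been measured and on what is new or still open speak of the compounds shown alone.

In a functional assay on PC-3 cells (Homo sapiens) (a lower number here means a stronger inhibitor of growth, a higher number a weaker inhibitor of growth), compound 2 `O=S(=O)(/C=C/c1ccc(Cl)c(Cl)c1)Cc1ccc(Nc2ncnc3ccccc23)cc1` gives 35000 nM, the higher of the two numbers, and compound 1 `O=S(=O)(/C=C/c1ccc(F)cc1)Cc1ccc(Nc2ncnc3ccccc23)cc1` gives 1000 nM. Compound 3 `O=S(=O)(/C=C/c1ccc(Br)cc1)Cc1ccc(Nc2ncnc3ccccc23)cc1` remains unmeasured. Its structural change is 4-bromophenyl in place of 3,4-dichlorophenyl on a double-bonded chain carbon bound to a double-bonded chain carbon, with 4-bromophenyl in place of 3,4-dichlorophenyl. Among the measured compounds shown here, one measured step bears on it, at the same place: a 35-fold higher number from compound 1 to compound 2 (1.54 log units; beyond the scatter), which is large. A move to a lower number is therefore expected, of a smaller size than that step. The expected step is a 5.8-fold lower number from compound 2 to compound 3 (0.77 log units; beyond the scatter). For compound 3 the estimate is 6000 nM, with an expected range from 1000 nM to 30000 nM.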

Compound 3, concentration for 50% growth inhibition: 42000 nM
Beside the measured number, compound 3's estimate is 7.0-fold (0.85 log units) below it; the whole stated range lies below it.
By their numbers in this assay, from the lowest: compound 1; then compounds 2 and 3 (each within the scatter of the next).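

In this assay the exchange at this place gives a 1.2-fold higher number from compound 2 to compound 3 (0.08 log units; within the scatter) so 4-bromophenyl and 3,4-dichlorophenyl read alike here, and a dichloro pattern is not required for the high number. Bromo in place of fluoro on an aromatic carbon gives a 42-fold higher number from compound 1 to compound 3 (1.62 log units; beyond the scatter) so a single halogen exchange is enough for a large step, and among these three only compound 1, the fluoro compound, holds the lower number. Nothing available explains why these steps fall as they do. The compounds shown leave open how an unsubstituted phenyl, a 4-chlorophenyl or a 4-methoxyphenyl would read at this place. They also leave open whether any group other than fluoro gives a number as low.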